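Removing a tert-butoxycarbonyl Group Across Two Related Amides

This account rests on a few compounds, and the source may have more. Where it says the series, first, only, none or still open, it means among the compounds named here.

Compound 1 `CC(C)[C@H](NC(=O)c1cc(Cl)ccc1OCCCNC(=O)OC(C)(C)C)C(=O)Nc1ccc([N+](=O)[O-])cc1Cl` was examined in a functional assay on MCF7 cells (Homo sapiens) for inhibition, read by MTT assay, with a stated time of 72 h; on this read-out higher numbers stand for weaker inhibition and lower numbers for stronger inhibition. In this assay compound 1 gives > 10000 nM, which is a limit of the assay rather than a number. Compound 2 `CC(C)[C@H](NC(=O)c1cc(Cl)ccc1OCCCN)C(=O)Nc1ccc([N+](=O)[O-])cc1Cl` carries the change (hydrogen in place of tert-butoxycarbonyl on an amine nitrogen). In this assay compound 2 gives > 10000 nM, again a limit. The step that the two limits leave unreadable from compound 1 to compound 2 therefore cannot be sized. Compound 3 `CC(C)[C@H](NC(=O)c1cc(Cl)ccc1OCCNC(=O)OC(C)(C)C)C(=O)Nc1ccc(F)c(F)c1` rests on a different core, and the difference between the core of compound 3 and the core of compound 1 is not broken down here. In this assay compound 3 gives > 10000 nM, also a limit. All three results sit at the limit of > 10000 nM in this assay, at which 3 of the 3 values shown sit. Compound 4 `CC(C)[C@H](NC(=O)c1cc(Cl)ccc1OCCN)C(=O)Nc1ccc(F)c(F)c1` differs from compound 3 by hydrogen in place of tert-butoxycarbonyl on an amine nitrogen, the same change as that from compound 1 to compound 2, made at the same kind of place. Because the earlier instance gave a step that the two limits leave unreadable from compound 1 to compound 2, the step from compound 3 to compound 4 is expected to be a step that the limit leaves unreadable from compound 3 to compound 4, with no real movement foreseen. Compound 4 is therefore expected to give about 15000 nM in this assay, most likely reported as a limit again, within a range from 5000 nM to 50000 nM.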

Compound 4, half-maximal inhibitory concentration: > 10000 nM
Compound 4 ended at the assay's limit; the forecaster's own chance of this, stated with the estimate: 80%; the middle value is on the limit's open side.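

In this assay compound 4 gives > 10000 nM, which is a limit of the assay and not a number. Compound 3 also stands at a limit, so no step can be read between compound 3 and compound 4. The whole set shares one position: the limit of > 10000 nM in this assay, at which 4 of the 4 values shown sit. The compounds shown leave open whether replacing tert-butoxycarbonyl with hydrogen changes inhibition at all.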